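Amide side-chain methylation in a cytotoxicity series

A few compounds are considered here, and "the series" means these few. Any claim that something is new, unique, unknown or untested is made for them only; others in the source may bear on it.

Compound 1 `CNC(=O)Cn1nc(N)c2c(C(F)(F)F)cc(-c3ccccc3)nc21` gives 15300 nM in a functional assay on A549 cells (Homo sapiens) for cytotoxicity, read by MTT assay, with a stated time of 24 h; on this read-out lower numbers stand for stronger inhibition and higher numbers for weaker inhibition. Compound 2 `CCNC(=O)Cn1nc(N)c2c(C(F)(F)F)cc(-c3ccccc3)nc21` carries methyl in place of hydrogen on a saturated chain carbon bound to an amide-type nitrogen and gives 18800 nM in this assay; the step of a 1.2-fold higher number from compound 1 to compound 2 (0.09 log units; within the scatter). Compound 3 `Nc1nn(CC(=O)NCC(=O)O)c2nc(-c3ccccc3)cc(C(F)(F)F)c12` differs from compound 1 by carboxy in place of hydrogen on a saturated chain carbon bound to an amide-type nitrogen. In this assay compound 3 gives 19900 nM; a 1.3-fold higher number from compound 1 to compound 3 (0.11 log units; within the scatter), and a 1.1-fold higher number from compound 2 to compound 3 (0.02 log units; within the scatter). All three numbers lie within the scatter of one another.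

Compound 4 `CC(NC(=O)Cn1nc(N)c2c(C(F)(F)F)cc(-c3ccccc3)nc21)C(=O)O` is not yet measured. From compound 3 to compound 4 the change is methyl in place of hydrogen on a saturated chain carbon bound to an amide-type nitrogen and a carbonyl carbon. This is the same kind of change as from compound 1 to compound 2, not the same one: in compound 4 the carbon receiving the methyl is bound to an amide-type nitrogen and a carbonyl carbon, whereas in compound 2 it is bound to an amide-type nitrogen only. The two cores differ in the way already given for compound 3 against compound 1.

For the measured compounds named here, the step from compound 3 to compound 4 in this assay is expected to be a 1.1-fold higher number from compound 3 to compound 4 (0.04 log units; within the scatter), beside the earlier 1.2-fold higher number from compound 1 to compound 2 (0.09 log units; within the scatter), resting on that single precedent and on the flat set of values so far. Compound 4 is estimated at 22000 nM, with a range from 10000 nM to 45000 nM.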

Compound 4, half-maximal inhibitory concentration: 25600 nM
Estimate against measurement, compound 4: 1.2-fold (0.07 log units) below; low and high end bracket the measured number.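

Methyl in place of hydrogen on the saturated chain carbon gives a 1.3-fold higher number from compound 3 to compound 4 (0.11 log units; within the scatter) in this assay, and this step reads the same on both cores: the same change on two cores in this assay, a 1.2-fold higher number (0.09 log units; within the scatter) from compound 1 to compound 2 and a 1.3-fold higher number (0.11 log units; within the scatter) from compound 3 to compound 4, 1.0-fold (0.02 log units) apart, within the scatter of two such steps. Carboxy in place of hydrogen gives a 1.4-fold higher number from compound 2 to compound 4 (0.13 log units; within the scatter), and it also reads the same on both cores: the same change on two cores in this assay, a 1.3-fold higher number (0.11 log units; within the scatter) from compound 1 to compound 3 and a 1.4-fold higher number (0.13 log units; within the scatter) from compound 2 to compound 4, 1.0-fold (0.02 log units) apart, within the scatter of two such steps. With both changes taken together, a 1.7-fold higher number from compound 1 to compound 4 (0.22 log units; within the scatter) also stays within the scatter, so the agreement holds only among steps too small to read as effects, and it does not show that a step of real size would carry from one core to another.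

The compounds shown leave open whether any group on this amide side chain can take the numbers clear of the scatter. A longer chain on the amide nitrogen, an amine in place of the carboxylic acid, or an ester of that acid would each bear on this question.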